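Cytotoxicity of Three Closely Related Compounds

The source may report more compounds than this note shows. Statements on the series, on what has been measured and on what is new or still open speak of the compounds shown alone.

In an ADME assay on BJ cells (Homo sapiens) for cytotoxicity, with a stated time of 72 h (a lower number here means that less compound is needed, a higher number that more compound is needed for the effect), compound 1 `CSc1ccccc1NC(=O)Nc1cc(C)nc2ccccc12` gives only a limit, > 25000 nM. Compound 2 `Cc1cc(NC(=O)Nc2ccccc2C(N)=O)c2ccccc2n1` likewise gives only a limit in this assay, > 25000 nM. The step that the two limits leave unreadable from compound 1 to compound 2 therefore cannot be sized. Compound 3 `Cc1cc(NC(=O)Nc2ccccc2[N+](=O)[O-])c2ccccc2n1` differs from compound 2 as follows: nitro in place of carbamoyl on an aromatic carbon. Among the measured compounds shown here, the single measured step bears on this change only through the fact that both of its values sit at the same limit, (the limit of > 25000 nM in this assay, at which 2 of the 2 values shown sit). No step beyond the scatter is expected in this assay. Compound 3 is therefore expected to give about 25000 nM, within 8000 nM to 60000 nM. The expected step is a number no higher from compound 2 to compound 3 (the limit leaves the size open).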

Compound 3, half-maximal effective concentration in the BJ assay: > 25000 nM
Compound 3 ended at the assay's limit (the forecaster's own chance of this, stated with the estimate: 75%); the middle value sits exactly at the limit.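

No new step can be read in the BJ assay among compound 1, compound 2 and compound 3, since all three stand at one limit: the limit of > 25000 nM in the BJ assay, at which 3 of the 3 values shown sit.

In a physicochemical assay for solubility, at pH 7.4 (a lower number here means a less soluble compound, a higher number a more soluble compound), compound 2 gives 200 nM and compound 3 gives 200 nM with no change at the digits printed from compound 2 to compound 3 (within the scatter) between them.

The compounds shown leave open at what concentration any of them would reach the half-maximal effect in the BJ assay at all.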